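The source may hold more compounds than are shown below. What is called first, only, known or untested is meant among the compounds shown, and "the series" means these compounds.

Measured compounds in a functional assay on M14 cells (Homo sapiens) for inhibition, read by sulforhodamine B assay, with a stated time of 48 h; on this read-out lower numbers stand for stronger inhibition of growth and higher numbers for weaker inhibition of growth:
compound 1 `Nc1cc(N)c2nc(-c3ccccc3)c(NCc3ccc(Cl)c(Cl)c3)nc2c1`: 34700 nM
compound 2 `COc1ccc(CNc2nc3cc(N)cc(N)c3nc2-c2ccccc2)cc1OC`: 7760 nM

Compound 2 has the lowest number of the two; the step of a 4.5-fold lower number from compound 1 to compound 2 (0.65 log units; beyond the scatter) separates it from compound 1. Compound 3 `COc1cc(CNc2nc3cc(N)cc(N)c3nc2-c2ccccc2)cc(OC)c1OC` differs from compound 2 by methoxy in place of hydrogen on an aromatic carbon. Among the compounds with values here, the one measured step exchanges one pair of ring substituents for another and does not test a further methoxy on the same ring, so it bears only loosely on this change. A small step, within the scatter, is expected, a 1.3-fold lower number from compound 2 to compound 3 (0.11 log units; within the scatter). Compound 3 is therefore estimated at 6000 nM, in the range 2500 nM to 15000 nM.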

Compound 3, concentration for total growth inhibition: 18200 nM
Beside the measured number, compound 3's estimate is 3.0-fold (0.48 log units) below it, and the stated range ends below it.
By their numbers in this assay, from the lowest: compound 2; then compounds 3 and 1 (each within the scatter of the next).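

In this assay, methoxy in place of hydrogen on the aromatic carbon ortho to a methoxy group gives a 2.3-fold higher number from compound 2 to compound 3 (0.37 log units; beyond the scatter) and so weakens growth inhibition, a modest step but one beyond the scatter. The earlier step exchanged one pair of ring substituents for another, whereas this one shows that adding a methoxy to the ring of compound 2 costs activity in this one pair. Nothing measured here accounts for the shift.

From the compounds shown here alone, whether ethoxy, hydroxy or an amine on this same ring carbon would give a similar step remains open. Also open, going by these compounds, is whether methoxy here has the same effect with the other ring substituents.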